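A few compounds are considered here, and "the series" means these few. Any claim that something is new, unique, unknown or untested is made for them only; others in the source may bear on it.

In a functional assay on NIH3T3 cells (Mus musculus) (on this read-out lower numbers stand for an effect already at smaller amounts and higher numbers for an effect only at larger amounts of compound), the measured compounds stand as follows.
Compound 1 `Cn1cncc1C(OCc1ccc(C#N)cc1C#Cc1ccccn1)c1ccc(C#N)cc1` gives > 0.1 nM, which is a limit of the assay.
Compound 2 `Cn1cncc1C(OCc1ccc(C#N)cc1/C=C/c1ccc([N+](=O)[O-])cc1)c1ccc(C#N)cc1` gives 2.24 nM.
Compound 3 `Cn1cncc1C(OCc1ccc(C#N)cc1C#Cc1ccc(-c2ccccc2)cc1)c1ccc(C#N)cc1` gives > 0.1 nM, also a limit of the assay.

Compound 1 therefore stands at a limit, and one further value sits there too (the limit of > 0.1 nM in this assay, at which 2 of the 3 values shown sit). The change to compound 4 `Cn1cncc1C(OCc1ccc(C#N)cc1C#CCCc1ccccc1)c1ccc(C#N)cc1` is phenethyl in place of pyridin-2-yl on a triple-bonded carbon. Two measured steps start from compound 1: a step that the limit leaves unreadable from compound 1 to compound 2 and a step that the two limits leave unreadable from compound 1 to compound 3. For the measured compounds named here, neither has a readable size, since compound 1 itself is only known as a limit, so no step in this set fixes the effect of a change on the triple-bonded carbon. Compound 4 is expected to give 1 nM, within 0.1 nM to 30 nM, which would mean a step that the limit leaves unreadable from compound 1 to compound 4, with a substantial chance that only a limit is reported once more.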

Compound 4, half-maximal effective concentration: 130 nM
Compound 4: middle estimate off by 130-fold (2.11 log units), on the low side; measured number outside the range, above it.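

For the compounds shown here, with compound 4, a group on the triple-bonded carbon gives a measured number rather than a limit in this assay, and this yields the one readable step: a 58-fold higher number from compound 2 to compound 4 (1.76 log units; beyond the scatter). That step exchanges 2-(4-nitrophenyl)ethenyl for 4-phenylbut-1-yn-1-yl as a whole, so it does not separate the triple bond from the phenethyl end. The steps to compound 4 from compound 1 and from compound 3 cannot be read: the limit of > 0.1 nM in this assay, at which 2 of the 4 values shown sit.

As far as these compounds go, it remains open how a carboxylic acid or a chain ending in an amine on the triple-bonded carbon would compare with phenethyl.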